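The source may hold more compounds than are shown below. What is called first, only, known or untested is meant among the compounds shown, and "the series" means these compounds.

Of the compounds shown here, three sharing one core have been measured in an assay on Sf9 cells for inhibition of protein deacetylase HDAC6 (Homo sapiens), read by fluorescence, with a stated time of 40 min, tested at 100 nM; on this read-out lower numbers stand for less inhibition and higher numbers for more inhibition at the one concentration tested (going by the name of the read-out). Compound 1 `O=C(NO)c1ccc(NCc2nc(-c3ccccc3)nn2-c2ccccc2Cl)cc1` gives 64.6%, compound 3 `COc1ccc(-n2nc(-c3ccccc3)nc2CNc2ccc(C(=O)NO)cc2)cc1` gives 63.4%, and compound 2 `O=C(NO)c1ccc(NCc2nc(-c3cccnc3)nn2-c2ccccc2)cc1` gives 57.7%. Compound 2 stands lowest of the three numbers, yet its distance to compound 3 and to compound 1 is within the usual scatter of repeated measurements, so the three cannot be told apart. For the measured compounds named here, the only step between two compounds that differ in one place is a number 1.2 percentage points lower from compound 1 to compound 3 (within the scatter), which lies within the scatter.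

Compound 4 `O=C(NO)c1ccc(NCc2nc(-c3ccsc3)nn2-c2ccccc2)cc1` has not yet been measured in this assay. It differs from compound 2 in one place: thiophen-3-yl in place of pyridin-3-yl on an aromatic carbon. Going by the values given here, this change sits on an aromatic carbon of the shared core, whereas the one measured step exchanged a group on an aromatic nitrogen, so no measured step bears on it directly. Compound 1 and compound 3 carry a phenyl group at that carbon, and their numbers in this assay lie within the scatter of the number for compound 2, so exchanging one ring for another at this carbon has so far not moved the read-out beyond the scatter. The expected step of a number 3.3 percentage points higher from compound 2 to compound 4 (within the scatter) is therefore none beyond the scatter. Compound 4 is estimated to give 61% in this assay, with a range from 47% to 75%.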

Compound 4, a percentage reported as inhibition, at one concentration (the size of the read-out at that concentration, not a potency): 53.4%
For compound 4 the middle estimate is 7.6 percentage points above the measured one; measured number inside the range.
By their numbers in this assay, from the lowest: compounds 4, 2, 3 and 1 (each within the scatter of the next, the first and the last beyond it).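

In this assay, the exchange of pyridin-3-yl for thiophen-3-yl gives the first step measured between two compounds that differ only on this aromatic carbon of the shared core: a number 4.3 percentage points lower from compound 2 to compound 4 (within the scatter). For the compounds shown here, this pair therefore shows directly that a six-membered aromatic ring with a nitrogen and a five-membered aromatic ring with a sulfur cannot be told apart at this position, even though the two rings differ in size and hetero atom; the earlier compounds could suggest this only indirectly, as they also differ in other places. No measurement here accounts for the size of this step.

All the groups shown on this carbon are aromatic rings, so it remains open whether the read-out would stay within the scatter with a group of another kind there, such as an amine, a carboxylic acid or a longer alkyl chain. As far as these compounds go, since each compound is tested at a single concentration, it also remains open whether compound 2 and compound 4 would still be indistinguishable at other concentrations.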